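From Methoxy to Fluoro on an Aromatic Carbon

The source may report more compounds than this note shows. Statements on the series, on what has been measured and on what is new or still open speak of the compounds shown alone.

In a functional assay on NCI-H661 cells (Homo sapiens) for antiproliferative activity, read by MTT assay, with a stated time of 72 h (on this read-out higher numbers stand for weaker inhibition and lower numbers for stronger inhibition), compound 1 `Cc1ccc(-c2noc(CCCCCCC(=O)C(F)(F)F)n2)cc1` gives 18700 nM and compound 2 `COc1ccc(-c2noc(CCCCCCC(=O)C(F)(F)F)n2)cc1` gives 5050 nM as the lower of the two numbers. Compound 3 `O=C(CCCCCCc1nc(-c2ccc(F)cc2)no1)C(F)(F)F` has fluoro in place of methoxy on an aromatic carbon and has not yet been measured. For the measured compounds named here, the one measured step bearing on this is a 3.7-fold lower number from compound 1 to compound 2 (0.57 log units; beyond the scatter) for methoxy in place of methyl, modest in size, and losing methoxy may give back part of it. A modest rise is therefore expected in this assay, with a 2.2-fold higher number from compound 2 to compound 3 (0.34 log units; beyond the scatter) as the estimated step. Compound 3 is estimated at 11000 nM (range 4000 nM to 28000 nM).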

Compound 3, half-maximal inhibitory concentration: 12700 nM
Compound 3: the middle estimate sits 1.2-fold (0.06 log units) below what was measured; low and high end bracket the measured number.
By their numbers in this assay, from the lowest: compound 2; then compounds 3 and 1 (each within the scatter of the next).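

In this assay, fluoro in place of methoxy gives a 2.5-fold higher number from compound 2 to compound 3 (0.40 log units; beyond the scatter), so at this position methoxy stands apart from fluoro as well as from methyl. Fluoro and methyl cannot be told apart here, with a 1.5-fold lower number from compound 1 to compound 3 (0.17 log units; within the scatter). Nothing measured here explains why methoxy stands apart. On these data alone, whether another group at this position, such as an amine or a hydroxyl, would match methoxy stays open. So does whether methoxy would keep its edge with a longer chain on the shared core.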